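A few compounds are considered here, and "the series" means these few. Any claim that something is new, unique, unknown or untested is made for them only; others in the source may bear on it.

Among the compounds with values here, compound 2 `O=C(Nc1cccc(-n2cc(-c3ccncc3)c(-c3cc(O)cc(Cl)c3)n2)c1)c1cc(C(F)(F)F)cc(C(F)(F)F)c1` and compound 1 `COc1cc(Cl)cc(-c2nn(-c3cccc(NC(=O)c4cccc(C(F)(F)F)c4)c3)cc2-c2ccncc2)c1` share one core and differ in two places at once, so no single step between them can be read. In a functional assay on IGROV-1 cells (Homo sapiens) for inhibition, read by sulforhodamine B assay, with a stated time of 48 h, tested at 10 uM (a lower number here means a stronger effect, a higher number a weaker effect of the compound at the concentration tested), compound 2 gives 73%, and compound 1 gives 80.7%, two readings that lie within the usual scatter of each other. Compound 3 `COc1cc(Cl)cc(-c2nn(-c3cccc(NC(=O)c4cc(C(F)(F)F)cc(C(F)(F)F)c4)c3)cc2-c2ccncc2)c1` is compound 2 with one change, (methyl in place of hydrogen on an oxygen on an aromatic ring). Within the data shown here, with no measured step of this kind to lean on, the expected step of a number 4 percentage points higher from compound 2 to compound 3 (within the scatter) is small, in no particular direction, and within the scatter. Compound 3 is therefore estimated at 77%, between 62% and 91%.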

Compound 3, a percentage reported as activity, at one concentration (the size of the read-out at that concentration, not a potency): 100%
Compound 3: the middle estimate sits 23 percentage points below what was measured, and the stated range ends below it.
By their numbers in this assay, from the lowest: compounds 2 and 1 (each within the scatter of the next); then compound 3.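

In this assay, putting methyl on the oxygen of the 3-chloro-5-hydroxyphenyl ring gives a number 27 percentage points higher from compound 2 to compound 3 (beyond the scatter) and so a weaker effect, the first readable step showing that this change at this position can matter. With the methoxy group kept, adding a second trifluoromethyl on an aromatic carbon gives a number 19.3 percentage points higher from compound 1 to compound 3 (beyond the scatter) and also weakens the effect. Nothing shown explains either step. On these data alone, an ethyl group on this oxygen or an amine in place of the hydroxy remains open. So does whether the methyl step holds with only one trifluoromethyl present.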